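The source may hold more compounds than are shown below. What is called first, only, known or untested is meant among the compounds shown, and "the series" means these compounds.

Compound 1 `COc1ccccc1Oc1c(N)nc(-c2ccc(C)cc2)nc1Cl` carries a chloro group on the shared core and, in a functional assay on B16 cells (Mus musculus) for cytotoxicity, read by CCK-8 assay, with a stated time of 24 h (on this read-out higher numbers stand for weaker inhibition and lower numbers for stronger inhibition), compound 1 gives 17400 nM. Compound 2 `COc1ccccc1Oc1c(N)nc(-c2ccc(C)cc2)nc1OCCO` replaces that chloro with a 2-hydroxyethoxy group, and in this assay compound 2 gives 8430 nM. Going by the values given here, that single change gives a 2.1-fold lower number from compound 1 to compound 2 (0.31 log units; beyond the scatter), so compound 2 holds the lowest number of the two measured so far.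

Compound 3 `COc1ccccc1Oc1c(N)nc(-c2ccc(F)cc2)nc1OCCO` keeps the 2-hydroxyethoxy group of compound 2 and differs from it only in this way: fluoro in place of methyl on an aromatic carbon. Cut one bond further out, the change reads 4-methylphenyl to 4-fluorophenyl. Among the compounds with values here, no measured step touches this ring; the one measured step, from compound 1 to compound 2, concerns a different group on the core and offers no guide here. With nothing to lean on, the expected step for compound 3 in this assay is a 1.1-fold higher number from compound 2 to compound 3 (0.03 log units; within the scatter), which is within the scatter. Compound 3 is therefore estimated to give 9000 nM, with a range from 4000 nM to 20000 nM.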

Compound 3, half-maximal inhibitory concentration: 30100 nM
Compound 3: the middle estimate sits 3.3-fold (0.52 log units) below what was measured; measured number above the stated range.
By their numbers in this assay, from the lowest: compound 2; then compounds 1 and 3 (each within the scatter of the next).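

The ring bearing the 4-methylphenyl group is not a neutral place in this assay: with fluoro in place of methyl on an aromatic carbon, para to a large group, the result is a 3.6-fold higher number from compound 2 to compound 3 (0.55 log units; beyond the scatter). This exchange of one heavy atom for one moves the number in the opposite direction to the earlier change on the core, which gave a 2.1-fold lower number from compound 1 to compound 2 (0.31 log units; beyond the scatter), so a small change on this ring is enough to step beyond the scatter. No measurement shown here explains this step.

With only methyl and fluoro seen at this place, the compounds shown cannot separate an effect of adding fluoro from one of losing methyl. On these data alone, whether methoxy, an amine or a longer alkyl chain on this ring would give a lower or a higher number remains open, as does whether the step would be the same with chloro on the core.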